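This account rests on a few compounds, and the source may have more. Where it says the series, first, only, none or still open, it means among the compounds named here.

Compound 1 `COc1ccc(C)cc1-c1c(C)nn(-c2nc(-c3ccc(Cl)c(Cl)c3)c(SC(C)C)s2)c1C(=O)O` is the reference point of the series. Within the data shown here, in a functional assay on BJAB cells (Homo sapiens) for antiproliferative activity, with a stated time of 4 days (on this read-out higher numbers stand for an effect only at larger amounts of compound and lower numbers for an effect already at smaller amounts), compound 1 gives 9500 nM, the highest number among the three compounds measured so far. Compound 2 `Cc1ccccc1-c1c(C)nn(-c2nc(-c3ccc(Cl)c(Cl)c3)c(SC(C)C)s2)c1C(=O)O` gives 5500 nM in this assay, and the step of a 1.7-fold lower number from compound 1 to compound 2 (0.24 log units; within the scatter) exchanges only the aryl group on the five-membered ring. Compound 3 `Cc1c(-c2cc(Cl)cc(Cl)c2)c(C(=O)O)nn1-c1nc(-c2cc(Cl)cc(Cl)c2)c(SC(C)C)s1` gives 2000 nM in this assay; it differs from compound 1 at two places, so its number can only be read as a loose lower bracket for the series.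

Compound 4 `COc1cc(C#N)cc(-c2c(C)nn(-c3nc(-c4ccc(Cl)c(Cl)c4)c(SC(C)C)s3)c2C(=O)O)c1` is not yet measured. It differs from compound 1 by 3-cyano-5-methoxyphenyl in place of 2-methoxy-5-methylphenyl on an aromatic carbon. Among the measured compounds shown here, the only measured step at this position, from compound 1 to compound 2, stayed within the scatter, and no measured pair swaps a methyl for a nitrile or shifts the methoxy group, so nothing in the data points to a decisive change. The expectation for compound 4 in this assay is therefore a step of a 1.4-fold lower number from compound 1 to compound 4 (0.13 log units; within the scatter) of uncertain direction and probably modest size, with the chance of a somewhat lower number left open by compound 3 and its 2000 nM. Compound 4 is estimated at 7000 nM in this assay, within a range from 2500 nM to 25000 nM.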

Compound 4, half-maximal effective concentration: 5200 nM
Compound 4: middle estimate off by 1.3-fold (0.13 log units), on the high side, within the range that was stated.
By their numbers in this assay, from the lowest: compound 3; then compounds 4, 2 and 1 (each within the scatter of the next).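

In this assay, a third aryl group at this carbon of the five-membered ring, 3-cyano-5-methoxyphenyl, gives a 1.8-fold lower number from compound 1 to compound 4 (0.26 log units; within the scatter) and a 1.1-fold lower number from compound 2 to compound 4 (0.02 log units; within the scatter), so neither step separates it from the earlier aryl groups. This adds a nitrile and a different arrangement of the methoxy group to what the earlier step at this position covered, and the three compounds with the 3,4-dichlorophenyl group remain indistinguishable in this read-out despite the differing aryl substituents. No measurement available here explains this outcome or connects it to any property of the groups exchanged.

The compounds shown do not say whether a more drastic exchange here, such as an unsubstituted phenyl, a pyridine ring or an aryl group carrying an amine, would move the number beyond the scatter. Compound 3 gives 2000 nM, but it differs from compound 1 at two places, so this value cannot be assigned to either place, and the contribution of the aryl group at this position remains unresolved.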